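Methoxycarbonyl on compound 2: expected cytotoxicity

The source may hold more compounds than are shown below. What is called first, only, known or untested is meant among the compounds shown, and "the series" means these compounds.

In an ADME assay on MT4 cells (Homo sapiens) for cytotoxicity, read by MTT assay (on this read-out higher numbers stand for lower toxicity in this test and lower numbers for higher toxicity in this test), compound 2 `O=C(CSc1nncnc1-c1ccccc1Cl)Nc1ccccc1Br` gives 73000 nM, the middle of three numbers, with compound 1 `Cc1cnc(NC(=O)CSc2nncnc2-c2ccccc2Cl)c(Br)c1` at 144000 nM and compound 3 `O=C(CSc1nncnc1-c1ccccc1Cl)Nc1ccc(Cl)cc1Cl` at 51000 nM. Compound 2 lies within the scatter of both: a 2.0-fold lower number from compound 1 to compound 2 (0.30 log units; within the scatter) and a 1.4-fold lower number from compound 2 to compound 3 (0.16 log units; within the scatter). Only the outer pair separates, and modestly: a 2.8-fold lower number from compound 1 to compound 3 (0.45 log units; beyond the scatter).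

Compound 4 `COC(=O)c1ccc(NC(=O)CSc2nncnc2-c2ccccc2Cl)c(Br)c1` differs from compound 2 by methoxycarbonyl in place of hydrogen on an aromatic carbon, meta to a bromo group and para to a large group. Within the data shown here, no measured step introduces this group, so the three steps above bear on it only indirectly, as changes to the group on the amide-type nitrogen. None of them exceeds the modest size of a 2.8-fold lower number from compound 1 to compound 3 (0.45 log units; beyond the scatter). No step beyond the scatter is therefore expected in this assay, and no direction is favoured. The expected step is a 1.1-fold lower number from compound 2 to compound 4 (0.05 log units; within the scatter). For compound 4 the estimate is 65000 nM, with an expected range of 30000 nM to 140000 nM.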

Compound 4, half-maximal cytotoxic concentration: 59000 nM
Beside the measured number, compound 4's estimate is 1.1-fold (0.04 log units) above it, within the range that was stated.
By their numbers in this assay, from the lowest: compounds 3, 4, 2 and 1 (each within the scatter of the next, the first and the last beyond it).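

Methoxycarbonyl in place of hydrogen on an aromatic carbon, meta to a bromo group and para to a large group, is the only change at this position among the compounds shown. In this assay, among these compounds, the change leaves a 1.2-fold lower number from compound 2 to compound 4 (0.09 log units; within the scatter) as the step, so this position carries methoxycarbonyl with no shift beyond the scatter, whereas the earlier steps only exchanged the whole group on the amide-type nitrogen. No measurement at hand accounts for this result.

From the compounds shown here alone, whether a carboxylic acid, an amine or a longer chain at this position would also stay within the scatter remains open. Also open, going by these compounds, is whether methoxycarbonyl would give a similar step on the aromatic rings of compound 1 and compound 3, whose numbers lie further apart.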